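Chloro for fluoro in two acetamide series

This account rests on a few compounds, and the source may have more. Where it says the series, first, only, none or still open, it means among the compounds named here.

Among the compounds with values here, compound 1 `O=C(CSc1nc(Nc2ccccc2)c2ccccc2n1)Nc1ccc(F)cc1` is the first of the compounds considered. In a functional assay on MGC-803 cells (Homo sapiens) for inhibition, read by MTT assay, with a stated time of 72 h (on this read-out lower numbers stand for stronger inhibition and higher numbers for weaker inhibition), compound 1 gives only a limit, > 50000 nM. Compound 2 `O=C(CSc1nc(Nc2ccccc2)c2ccccc2n1)Nc1ccc(Cl)cc1` differs from it by chloro in place of fluoro on an aromatic carbon. In this assay compound 2 gives 40400 nM, a step of an at least 1.2-fold lower number from compound 1 to compound 2 (0.09 log units; that floor lies within the scatter). That floor rests on (the limit of > 50000 nM in this assay, at which 1 of the 3 values shown sits). Compound 3 `C=CC(=O)Nc1cccc(NC(=O)CSc2nc(Nc3ccccc3F)c3ccccc3n2)c1` is built on another core; the difference between the two cores is not broken down here. In this assay compound 3 gives 26100 nM, which lies within the scatter of compound 2. Compound 4 `C=CC(=O)Nc1cccc(NC(=O)CSc2nc(Nc3ccccc3Cl)c3ccccc3n2)c1`, not yet measured, differs from compound 3 by chloro in place of fluoro on an aromatic carbon. Within the data shown here, this is the same kind of change as the one from compound 1 to compound 2, but its place is ortho to a large group rather than para to a large group. Because the measured step of an at least 1.2-fold lower number from compound 1 to compound 2 (0.09 log units; that floor lies within the scatter) is small, a similarly small step is expected in this assay. Compound 4 is therefore expected at 20000 nM, between 8000 nM and 50000 nM. The expected step is a 1.3-fold lower number from compound 3 to compound 4 (0.12 log units; within the scatter).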

Compound 4, half-maximal inhibitory concentration: 20700 nM
Beside the measured number, compound 4's estimate is 1.0-fold (0.01 log units) below it, and the stated range covers the measured number.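

In this assay, within the data shown here, chloro in place of fluoro, here ortho to a large group, gives a 1.3-fold lower number from compound 3 to compound 4 (0.10 log units; within the scatter), so the change again makes no step that stands out from the scatter. The pair shows that the change stays small wherever it can be read on these two cores, but it does not show that the two cores respond alike: the same change on two cores in this assay, an at least 1.2-fold lower number (0.09 log units; that floor lies within the scatter) from compound 1 to compound 2 and a 1.3-fold lower number (0.10 log units; within the scatter) from compound 3 to compound 4; the limit leaves it open whether they differ. The earlier step is only a floor, and the size of that step stays unknown for this reason: the limit of > 50000 nM in this assay, at which 1 of the 4 values shown sits.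

The compounds shown leave open what other groups would do in the place of fluoro and chloro on this ring, such as bromo, methyl, methoxy, an amine or a carboxylic acid. They also leave open whether any such group would bring the numbers in this series well clear of the scatter around the values seen so far.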